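Sulfation of a sugar amide: expected effect on growth inhibition

This account rests on a few compounds, and the source may have more. Where it says the series, first, only, none or still open, it means among the compounds named here.

In a functional assay on A-375 cells (Homo sapiens), read by thymidine incorporation (on this read-out lower numbers stand for stronger inhibition and higher numbers for weaker inhibition), compound 2, with the structure `CCCCCCCC/C=C\CCCCCCCC(=O)N[C@H]1[C@@H](OCCCCCCCC)O[C@H](CO)[C@@H](O)[C@@H]1O`, gives 6 uM. Compound 3, with the structure `CCCCCCCC/C=C\CCCCCCCC(=O)N[C@H]1[C@@H](OCCCCCCCC)O[C@H](CO)[C@@H](O)[C@@H]1OS(=O)(=O)O`, carries the change sulfo in place of hydrogen on an oxygen on a saturated carbon on the same core, and in this assay compound 3 gives 16 uM. The step of a 2.7-fold higher number from compound 2 to compound 3 (0.43 log units; beyond the scatter) thus weakens inhibition by a modest amount.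

Compound 1 has the structure `C=CCCC(=O)N[C@H]1[C@@H](OCCc2ccccc2)O[C@H](CO)[C@@H](O)[C@@H]1O`. In this assay compound 1 gives only a limit, > 50 uM, and not a number; this is the limit of > 50 uM in this assay, at which 1 of the 3 values shown sits. How the core of compound 1 differs from the core of compound 2 is not broken down here.

Compound 4, with the structure `C=CCCC(=O)N[C@H]1[C@@H](OCCc2ccccc2)O[C@H](COS(=O)(=O)O)[C@@H](O)[C@@H]1O`, differs from compound 1 by sulfo in place of hydrogen on an oxygen on a saturated carbon. Going by the values given here, this is the same kind of change as the one from compound 2 to compound 3, but not the same: there the oxygen sat on a saturated carbon whose other neighbour is a saturated ring carbon, whereas here the other neighbour is a saturated chain carbon.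

In this assay compound 4 is expected to give 120 uM, somewhere between 50 uM and 400 uM. In this assay compound 1 already gives only a limit, > 50 uM. Given the direction of a 2.7-fold higher number from compound 2 to compound 3 (0.43 log units; beyond the scatter), the expected step that the limit leaves unreadable from compound 1 to compound 4 points the same way, and compound 4 is expected most likely to return only a limit as well.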

Compound 4, concentration for 50% inhibition: > 50 uM
Compound 4: a limit, no number; the forecaster's own chance of this, stated with the estimate: 90%; the middle value lies beyond the limit too.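

In this assay compound 4 gives > 50 uM, a limit and not a number. Compound 1 also gives only a limit, so no step between compound 1 and compound 4 can be read: the limit of > 50 uM in this assay, at which 2 of the 4 values shown sit.

The compounds shown leave open how far the sulfo group changes inhibition on the core of compound 1, and whether that change matches a 2.7-fold higher number from compound 2 to compound 3 (0.43 log units; beyond the scatter).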